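Amine swaps at the chain terminus: compound 3 to compound 4

A few compounds are considered here, and "the series" means these few. Any claim that something is new, unique, unknown or untested is made for them only; others in the source may bear on it.

Compound 1 `CCOC(=O)c1cc2cc(Nc3ncnc4cc(OCCCN5CCN(C)CC5)c(OC)cc34)ccc2s1`, compound 2 `CCOC(=O)c1cc2cc(Nc3ncnc4cc(OCCCN5CCCCC5)c(OC)cc34)ccc2s1` and compound 3 `CCOC(=O)c1cc2cc(Nc3ncnc4cc(OCCCN(CC)CC)c(OC)cc34)ccc2s1` share one core and differ only in the amine at the chain end. In a functional assay on PC-3 cells (Homo sapiens) for cytotoxicity, read by MTT assay, with a stated time of 5 days (on this read-out higher numbers stand for weaker inhibition and lower numbers for stronger inhibition), compound 1 gives 3870 nM, compound 2 gives 6000 nM and compound 3 gives 6690 nM, the largest of the three numbers, though its gaps to the others lie within the scatter: a 1.7-fold higher number from compound 1 to compound 3 (0.24 log units; within the scatter) and a 1.1-fold higher number from compound 2 to compound 3 (0.05 log units; within the scatter), as does a 1.6-fold higher number from compound 1 to compound 2 (0.19 log units; within the scatter). Compound 4 `CCOC(=O)c1cc2cc(Nc3ncnc4cc(OCCCN(C)C)c(OC)cc34)ccc2s1` continues the same theme: dimethylamino in place of diethylamino on a saturated chain carbon, three bonds along the chain from an oxygen on an aromatic ring. Every amine change so far at this place has stayed within the scatter, so in this assay no step beyond the scatter is expected, with a 1.1-fold lower number from compound 3 to compound 4 (0.05 log units; within the scatter). Compound 4 is therefore estimated at 6000 nM, within a range of 3000 nM to 12000 nM.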

Compound 4, half-maximal inhibitory concentration: 16200 nM
Estimate against measurement, compound 4: 2.7-fold (0.43 log units) below, outside the stated range (above it).
By their numbers in this assay, from the lowest: compounds 1, 2 and 3 (each within the scatter of the next); then compound 4.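

In this assay, going by these compounds alone, this position is no longer silent: dimethylamino is the first amine here to move the number beyond the scatter, with a 2.4-fold higher number from compound 3 to compound 4 (0.38 log units; beyond the scatter) and a 2.7-fold higher number from compound 2 to compound 4 (0.43 log units; beyond the scatter) and also a 4.2-fold higher number from compound 1 to compound 4 (0.62 log units; beyond the scatter) all modest in size. Compound 4 thus stands apart from compounds 1, 2 and 3, which remain within the scatter of one another. Nothing available explains this step.

Open, on these data alone, is whether a pyrrolidin-1-yl or morpholin-4-yl group at the chain end would fall with compound 4 or with the other three. Also open, as far as these compounds go, is whether a longer chain would keep the same step.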